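The source may report more compounds than this note shows. Statements on the series, on what has been measured and on what is new or still open speak of the compounds shown alone.

Working notes on the series. Compound 1 `CC(C)N1C(=O)C(Cc2ccc([N+](=O)[O-])cc2)COC12C=CC(=O)C=C2` reaches only the limit of an assay on isolated protein for inhibition of N-lysine methyltransferase SMYD2 (Homo sapiens), read by filter binding, with a stated time of 1 h (a higher number here means a weaker inhibitor, a lower number a stronger inhibitor), giving > 20000 nM. Compound 2 `CC(C)N1C(=O)C(Cc2cc(C(F)(F)F)ccc2Cl)COC12C=CC(=O)C=C2` likewise stops at a limit, > 20000 nM. Compound 3 `CN1C(=O)C(CCO)COC12C=CC(=O)C=C2` also returns a limit rather than a number, > 30000 nM. Compound 3 therefore stands nowhere distinct among the numbers shown: every result in the set is a limit, two at the limit of > 20000 nM in this assay, at which 2 of the 3 values shown sit, and one at the limit of > 30000 nM in this assay, at which 1 of the 3 values shown sits, so no ranking is possible. Compound 4 `CN1C(=O)C(CCNc2cccnc2)COC12C=CC(=O)C=C2` differs from compound 3 by (pyridin-3-yl)amino in place of hydroxy on a saturated chain carbon, two bonds along the chain from a saturated ring carbon. Among the compounds with values here, no measured step shows what such a change does, so the direction is open. The expected step of an at least 2.0-fold lower number from compound 3 to compound 4 (0.30 log units; that floor lies within the scatter) starts from a limit and is uncertain in size. Compound 4 is estimated at 15000 nM, within 2000 nM to 100000 nM, with a fair chance that only a limit is reported again.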

Compound 4, half-maximal inhibitory concentration: > 20000 nM
Compound 4 gave a limit, no number; the forecaster's own chance of this, stated with the estimate: 60%; middle value at least 1.3-fold (0.12 log units) away from the limit.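

Compound 3 and compound 4 both return only limits in this assay, so no step can be read between them. The compounds shown leave open whether (pyridin-3-yl)amino in place of hydroxy changes inhibition at all.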